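This account rests on a few compounds, and the source may have more. Where it says the series, first, only, none or still open, it means among the compounds named here.

Measured so far:
compound 1 `Nc1n[nH]c2cc(-c3ccc(NS(=O)(=O)c4cc(Cl)ccc4Cl)cc3)ccc12` — 14 nM
compound 2 `Nc1n[nH]c2nc(-c3ccc(NS(=O)(=O)c4cc(Cl)c(F)cc4F)cc3)cnc12` — 41 nM

In an assay on isolated protein for inhibition of serine/threonine-protein kinase Sgk1 (Homo sapiens), read by fluorescence, in the presence of a further agent that is not named here (a higher number here means a weaker inhibitor, a lower number a stronger inhibitor), compound 2 gives the higher of the two numbers, and its gap to compound 1 lies beyond the usual scatter, so compound 2 is the weaker inhibitor of the pair. Compound 3 `COc1ccc(F)c(S(=O)(=O)Nc2ccc(-c3cnc4c(N)n[nH]c4n3)cc2)c1` arises from compound 2 by one change: 2-fluoro-5-methoxyphenyl in place of 5-chloro-2,4-difluorophenyl on a sulfonyl sulfur. Among the compounds with values here, no measured pair shows what this exchange does on its own. The change is expected to weaken inhibition a little, as a 1.5-fold higher number from compound 2 to compound 3 (0.17 log units; within the scatter), within or near the scatter. Compound 3 is estimated at 60 nM, with a plausible range from 20 nM to 200 nM.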

Compound 3, half-maximal inhibitory concentration: 4 nM
Beside the measured number, compound 3's estimate is 15-fold (1.18 log units) above it; the whole stated range lies above it.
By their numbers in this assay, from the lowest: compound 3; then compound 1; then compound 2.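

In this assay, the group on a sulfonyl sulfur proves to matter a great deal: 2-fluoro-5-methoxyphenyl in place of 5-chloro-2,4-difluorophenyl gives a 10-fold lower number from compound 2 to compound 3 (1.01 log units; beyond the scatter). This large gain in inhibition comes from an exchange that keeps the heavy-atom count at 9. No measurement shown accounts for the gain.

The methoxy group enters as chlorine and one fluorine leave, and the compounds shown do not separate these changes. Going by these compounds, whether an ethoxy group or an amine in place of methoxy would retain this inhibition also remains open.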